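Compound 2 to compound 4: replacing 3-methylphenyl

The source may report more compounds than this note shows. Statements on the series, on what has been measured and on what is new or still open speak of the compounds shown alone.

For the measured compounds named here, in a functional assay on MCF7 cells (Homo sapiens) for cytotoxicity, read by MTT assay, with a stated time of 96 h (a lower number here means a stronger inhibitor, a higher number a weaker inhibitor), compound 2 (`COc1cc(C(=O)c2cn(-c3cccc(C)c3)cc2-c2cccc([N+](=O)[O-])c2)cc(OC)c1OC`) gives 880 nM as the highest number of the three measured so far. Compound 1 (`COc1cc(C(=O)c2cn(-c3cccc(C)c3)cc2-c2ccccc2Cl)cc(OC)c1OC`) gives 420 nM and compound 3 (`COc1cc(C(=O)c2cn(-c3cccc(C)c3)cc2-c2cccc(N)c2)cc(OC)c1OC`) gives 130 nM on the same read-out. Compound 4 (`COc1cc(C(=O)c2cn(-c3ccc(N)cc3)cc2-c2cccc([N+](=O)[O-])c2)cc(OC)c1OC`) keeps the 3-nitrophenyl group and carries 4-aminophenyl in place of 3-methylphenyl on an aromatic nitrogen. Going by the values given here, no measured step changes the group at that place, so the evidence is indirect. The closest guide is the amino in place of nitro change on an aromatic carbon, seen as a 6.8-fold lower number from compound 2 to compound 3 (0.83 log units; beyond the scatter) in the series. The step of a 3.2-fold lower number from compound 1 to compound 3 (0.51 log units; beyond the scatter) also ends at the amino compound. A move to a lower number is therefore expected in this assay but smaller than the first of these, since the amino group enters at a different place. The expected step is a 2.9-fold lower number from compound 2 to compound 4 (0.47 log units; beyond the scatter) and it remains uncertain. Compound 4 is estimated at 300 nM with 70 nM to 1200 nM as the expected range.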

Compound 4, half-maximal inhibitory concentration: 260 nM
Compound 4: the middle estimate sits 1.2-fold (0.06 log units) above what was measured, and the stated range covers the measured number.
By their numbers in this assay, from the lowest: compounds 3, 4 and 1 (each within the scatter of the next, the first and the last beyond it); then compound 2.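

In this assay, the group on the aromatic nitrogen of the five-membered aromatic ring proves able to shift the number, with a 3.4-fold lower number from compound 2 to compound 4 (0.53 log units; beyond the scatter) as the first step shown at this place. The step of a 6.8-fold lower number from compound 2 to compound 3 (0.83 log units; beyond the scatter) reached a lower number by replacing nitro with amino, whereas compound 4 keeps the 3-nitrophenyl group, so removing the nitro group is not required for a drop from compound 2. Nothing available bears on why the number falls.

Since the methyl group leaves as the amino group enters, the compounds shown do not separate the two contributions to this step. Also open, from the compounds shown here alone, is how plain phenyl, 4-hydroxyphenyl or 4-(dimethylamino)phenyl would read on this nitrogen, with the 3-nitrophenyl group kept.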